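The source may report more compounds than this note shows. Statements on the series, on what has been measured and on what is new or still open speak of the compounds shown alone.

Measured so far in a toxicity assay on MDCK cells (Canis lupus familiaris) for cytotoxicity, read by crystal violet staining, with a stated time of 48 h; on this read-out higher numbers stand for lower toxicity in this test and lower numbers for higher toxicity in this test:
compound 1, `CCc1ccc(CN(Cc2ccc(F)cc2)Cc2cc3ccc(C)cc3[nH]c2=O)cc1`, gives > 33000 nM
compound 2, `CCCCOc1ccc(CN(Cc2ccc(C(C)(C)C)cc2)Cc2cc3cc(C)ccc3[nH]c2=O)cc1`, gives > 5000 nM

Neither result is a number. For compound 1 the value > 33000 nM is a limit of this assay, as stated in the limit of > 33000 nM in this assay, at which 1 of the 2 values shown sits. For compound 2 the value > 5000 nM is also a limit, as stated in the limit of > 5000 nM in this assay, at which 1 of the 2 values shown sits. Among the measured compounds shown here, compound 2 therefore stands on a limit alone, and the single further value in this assay is a limit as well, so no step between measured compounds can be counted.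

The unmeasured compound 3, `Cc1ccc2[nH]c(=O)c(CN(Cc3ccc(C(C)(C)C)cc3)[C@H](C)c3ccc(F)cc3)cc2c1`, differs from compound 2 at one place: 1-(4-fluorophenyl)ethyl in place of 4-butoxybenzyl on an amine nitrogen. With both known values sitting at limits, no measured step sizes this change; the expected step is a step that the limit leaves unreadable from compound 2 to compound 3, that is nothing beyond the usual scatter. For compound 3 the estimated value in this assay is 40000 nM, within 10000 nM to 150000 nM, and a limit rather than a number is the likelier report.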

Compound 3, half-maximal cytotoxic concentration: > 5000 nM
Compound 3 gave a limit, no number; the forecaster's own chance of this, stated with the estimate: 70%; the middle value does not contradict the limit.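

In this assay compound 3 gives > 5000 nM, which is a limit, not a number. Among the compounds shown here, compound 2 also stands on a limit, so no step from compound 2 to compound 3 can be read. The compounds shown leave open whether 1-(4-fluorophenyl)ethyl in place of 4-butoxybenzyl on an amine nitrogen changes the result in this assay at all.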